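Cyclohexyl for tert-butyl on a melanin-concentrating hormone receptor antagonist

The compounds below may be only part of what the source reports. "The series", "measured", "known", "first", "only" and "open" are said of these compounds alone.

Compound 1 `CC(C)(C)c1cc(N)c2cc(NC(=O)/C=C/c3ccc(C(F)(F)F)cc3)ccc2n1`: 0.3 nM
Compound 2 `CCCc1cc(N)c2cc(NC(=O)/C=C/c3ccc(Br)cc3)ccc2n1`: 4 nM

In an assay on isolated protein for displacement of a labelled ligand from melanin-concentrating hormone receptor 1 (Homo sapiens) (on this read-out higher numbers stand for weaker inhibition and lower numbers for stronger inhibition), compound 1 gives 0.3 nM, the lowest of the two numbers; compound 2 gives 4 nM, a gap beyond the usual scatter. Compound 3 `Nc1cc(C2CCCCC2)nc2ccc(NC(=O)/C=C/c3ccc(C(F)(F)F)cc3)cc12` differs from compound 1 by one change: cyclohexyl in place of tert-butyl on an aromatic carbon. Going by the values given here, no measured pair shows this exact swap, so its effect is unknown. The step from compound 1 to compound 3 is expected to be small, probably within the scatter or a modest rise, as a 2.0-fold higher number from compound 1 to compound 3 (0.30 log units; within the scatter). Compound 3 is therefore estimated at 0.6 nM, between 0.15 nM and 3 nM.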

Compound 3, half-maximal inhibitory concentration: 1.2 nM
Beside the measured number, compound 3's estimate is 2.0-fold (0.30 log units) below it, and the stated range covers the measured number.
By their numbers in this assay, from the lowest: compound 1; then compound 3; then compound 2.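

Replacing tert-butyl with cyclohexyl on this aromatic carbon, next to the ring nitrogen, gives a 4.0-fold higher number from compound 1 to compound 3 (0.60 log units; beyond the scatter) in this assay. This position therefore tolerates a bigger carbon group that contains a ring, with only a modest loss: compound 3 still gives 1.2 nM on this read-out. Nothing available explains the rise.

Compound 2 differs from the others in more than one place, so it cannot show how a straight propyl chain compares here. On these data alone, how a phenyl ring or a nitrogen-containing piperidine ring would behave on this carbon remains open.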